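This account rests on a few compounds, and the source may have more. Where it says the series, first, only, none or still open, it means among the compounds named here.

In a functional assay on HepG2 cells (Homo sapiens) for antiproliferative activity, read by CCK-8 assay, with a stated time of 72 h (on this read-out lower numbers stand for stronger inhibition and higher numbers for weaker inhibition), compound 1 `CCC(C)n1cnc2c(NCc3ccc(C(=O)Nc4ccccc4N)cc3)nc(Cl)nc21` reads 2990 nM and compound 2 `Nc1ccccc1NC(=O)c1ccc(Cn2cnc3c(Nc4ccccc4)nc(Cl)nc32)cc1` reads 4180 nM with the two numbers within the usual scatter of each other. Compound 3 `Nc1ccccc1NC(=O)c1ccc(Cn2cnc3c(Nc4ccc(-c5ccccn5)cc4)nc(Cl)nc32)cc1` differs from compound 2 in one place, pyridin-2-yl in place of hydrogen on an aromatic carbon with pyridin-2-yl in place of hydrogen on an aromatic carbon. Among the measured compounds shown here, no measured pair shows what such an addition does, so in this assay only a modest step towards stronger inhibition is expected. The estimated change is a 1.9-fold lower number from compound 2 to compound 3 (0.28 log units; within the scatter) and it remains uncertain. Compound 3 is expected at 2200 nM within an estimated range of 600 nM to 8000 nM until it is measured.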

Compound 3, half-maximal inhibitory concentration: 30100 nM
The estimate for compound 3 lay 14-fold (1.14 log units) below the measured number; the measured number lies above the stated range.
By their numbers in this assay, from the lowest: compounds 1 and 2 (each within the scatter of the next); then compound 3.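

In this assay the position on the aromatic ring para to a large group does not simply tolerate extra bulk: adding pyridin-2-yl there gives a 7.2-fold higher number from compound 2 to compound 3 (0.86 log units; beyond the scatter), a clear loss of inhibition that the two earlier compounds could not reveal. Nothing available explains this loss. From the compounds shown here alone, it remains open whether a smaller group at the same position, such as fluorine or methoxy, would retain inhibition, and whether a plain phenyl ring would cost as much as pyridin-2-yl.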